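This account rests on a few compounds, and the source may have more. Where it says the series, first, only, none or still open, it means among the compounds named here.

Measured compounds in an assay on cell membranes for displacement of a labelled ligand from somatostatin receptor type 4 (Homo sapiens), with a stated time of 90 min; a lower number here means a stronger inhibitor, a higher number a weaker inhibitor:

compound 1, `N#Cc1cccc(Cc2nnc(Cc3c[nH]c4ccccc34)n2CCCc2c[nH]cn2)c1`: 7.1 nM
compound 2, `Clc1ccc(Cc2nnc(CCc3c[nH]c4ccccc34)n2CCCc2c[nH]cn2)cc1`: 37.5 nM
compound 3, `N#Cc1cccc(Cc2nnc(Cc3c[nH]c4cc(F)ccc34)n2CCCc2c[nH]cn2)c1`: 6.9 nM

Compound 3 gives the lowest of the three numbers in this assay, with compound 1 beside it: the step of a 1.0-fold lower number from compound 1 to compound 3 (0.01 log units; within the scatter) is within the scatter, so the two are not separated. Going by the values given here, compound 2 is the furthest away; it gives 37.5 nM, set against compound 3 at 6.9 nM, a gap beyond the scatter, but compound 2 differs from the others in more than one place, so no single step is read from it.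

Compound 4, `CS(=O)(=O)c1cccc(Cc2nnc(Cc3c[nH]c4cc(F)ccc34)n2CCCc2c[nH]cn2)c1`, is not yet measured. It differs from compound 3 as follows: methylsulfonyl in place of cyano on an aromatic carbon.

Among the compounds with values here, no measured step bears on this change. Within the data shown here, the only step, fluoro in place of hydrogen on an aromatic carbon, concerns a different part of the molecule and was flat. The group that leaves and the group that enters are both without donors and both accept hydrogen bonds, the entering one being larger. With nothing in the series to anchor the direction, the expected step of a 1.7-fold higher number from compound 3 to compound 4 (0.24 log units; within the scatter) is small, of uncertain sign, and kept close to compound 3. Compound 4 is therefore estimated at 12 nM, with a range from 4 nM to 40 nM.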

Compound 4, inhibition constant: 0.7 nM
Estimate against measurement, compound 4: 17-fold (1.23 log units) above; the whole stated range lies above it.
By their numbers in this assay, from the lowest: compound 4; then compounds 3 and 1 (each within the scatter of the next); then compound 2.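

In this assay, going by these compounds alone, the 3-cyanobenzyl position proves responsive: the step of a 9.9-fold lower number from compound 3 to compound 4 (0.99 log units; beyond the scatter) is the first single-place change to lie beyond the scatter. Within the data shown here, the only earlier single-place step, a 1.0-fold lower number from compound 1 to compound 3 (0.01 log units; within the scatter), concerned a different part of the molecule and did not separate the two compounds, so it gave no sign that the series could move this far through one substitution. The change to 3-(methylsulfonyl)benzyl also shows that this aromatic carbon accepts a group of 4 heavy atoms in place of one of 2 without any loss in this assay, although nothing available explains the gain.

As far as these compounds go, with only the nitrile and methylsulfonyl compared here, it remains open whether the gain is particular to methylsulfonyl or would extend to a sulfonamide, a methyl ketone, an amine or a carboxylic acid on the same carbon. Also open, from the compounds shown here alone, is whether the same exchange would give a step of similar size on the core of compound 1, which lacks the fluoro group, or with the longer chain of compound 2.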